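Compound 2 to compound 3: ring size on the nitrogen

The source may report more compounds than this note shows. Statements on the series, on what has been measured and on what is new or still open speak of the compounds shown alone.

Within the data shown here, in an ADME assay on S9 fraction from liver (Homo sapiens) for metabolic stability, with a stated time of 1 h (on this read-out lower numbers stand for a less stable compound and higher numbers for a more stable compound), compound 1 (`N#Cc1cnc(NCc2cnccc2C(F)(F)F)cc1N[C@H]1C[C@H](O)C1`) gives 96% and compound 2 (`N#Cc1cnc(NCc2cnccc2C(F)(F)F)cc1NC[C@H]1C[C@H](O)C1`) gives 93% with no separation between them, so compound 2 stands level with the only other measured compound. Among the measured compounds shown here, the single measured step is a number 3 percentage points lower from compound 1 to compound 2 (within the scatter) on exchanging 3-hydroxycyclobutyl for (3-hydroxycyclobutyl)methyl on a nitrogen on an aromatic ring. Compound 3 (`N#Cc1cnc(NCc2cnccc2C(F)(F)F)cc1N[C@H]1CC[C@@H](O)CC1`) is the next case, with 4-hydroxycyclohexyl in place of (3-hydroxycyclobutyl)methyl on that same nitrogen: 4-hydroxycyclohexyl in place of (3-hydroxycyclobutyl)methyl on a nitrogen on an aromatic ring. The measured step touched the same substituent and stayed small, so no change beyond the scatter is expected here. The expected move is a number 3 percentage points lower from compound 2 to compound 3 (within the scatter) in this assay and no more than that. No six-membered ring has been measured yet, so the range is kept wide. The estimate for compound 3 is 90% (76% to 100%).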

Compound 3, percent of the compound remaining: 33%
Beside the measured number, compound 3's estimate is 57 percentage points above it; measured number below the stated range.
By their numbers in this assay, from the lowest: compound 3; then compounds 2 and 1 (each within the scatter of the next).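

On the nitrogen on an aromatic ring, the substituent can decide the result in this assay and the read-out is not insensitive to this place as the first step alone suggested. With 4-hydroxycyclohexyl in place of (3-hydroxycyclobutyl)methyl the series shows a number 60 percentage points lower from compound 2 to compound 3 (beyond the scatter) and with 4-hydroxycyclohexyl in place of 3-hydroxycyclobutyl it shows a number 63 percentage points lower from compound 1 to compound 3 (beyond the scatter) while the two compounds with a four-membered ring stay within the scatter of each other. No evidence on the cause of this drop is at hand.

The compounds shown do not tell whether a five-membered ring such as 3-hydroxycyclopentyl would stay with the four-membered rings or fall with the six-membered one. Also open, as far as these compounds go, is whether 4-aminocyclohexyl, with an amine in place of the hydroxyl, would read like 4-hydroxycyclohexyl.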